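The compounds below may be only part of what the source reports. "The series", "measured", "known", "first", "only" and "open" are said of these compounds alone.

Measured compounds:
- compound 1 `Cc1ccc(-c2ccnc(C(=O)Nc3ccc(Oc4ccnc5[nH]ccc45)cc3)n2)cc1` gives 6140 nM
- compound 2 `O=C(Nc1ccc(Oc2ccnc3[nH]ccc23)cc1)c1cc(-c2ccccc2)ncn1` gives 240 nM
- compound 3 `O=C(Nc1ccc(Oc2ccnc3[nH]ccc23)c(F)c1)c1cc(-c2ccccc2)ncn1` gives 40 nM

Among the compounds with values here, in a functional assay on PC-3 cells (Homo sapiens) for cytotoxicity, read by MTT assay, with a stated time of 72 h (a higher number here means a weaker inhibitor, a lower number a stronger inhibitor), compound 3 stands with the lowest number of the three, and the only single change that leads to it is the step of a 6.0-fold lower number from compound 2 to compound 3 (0.78 log units; beyond the scatter), in which compound 3 carries a fluoro where compound 2 carries a hydrogen. Within the data shown here, compound 1 differs from compound 2 in more than one place, so the two values show only that compound 1 sits far higher.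

Compound 4 `O=C(Nc1ccc(Oc2ccnc3[nH]ccc23)c(F)c1)c1cc(-c2ccc(Br)cc2)ncn1` keeps everything in compound 3 and adds (bromo in place of hydrogen on an aromatic carbon). Among the measured compounds shown here, none of the measured steps touches the phenyl ring on the pyrimidine, so no step bears directly on this change, and the direction cannot be read from the data. Given that compound 3 already gives 40 nM, the account expects compound 4 to stay close to it, with the step of a 1.1-fold lower number from compound 3 to compound 4 (0.06 log units; within the scatter) estimated to fall within the scatter. Compound 4 is therefore estimated at 35 nM, in the range 10 nM to 130 nM.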

Compound 4, half-maximal inhibitory concentration: 11300 nM
Beside the measured number, compound 4's estimate is 320-fold (2.51 log units) below it; the measured number lies above the stated range.
By their numbers in this assay, from the lowest: compound 3; then compound 2; then compounds 1 and 4 (each within the scatter of the next).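

In this assay, within the data shown here, the change from phenyl to 4-bromophenyl gives a 280-fold higher number from compound 3 to compound 4 (2.45 log units; beyond the scatter), which shows that this ring position, untouched by the earlier steps, is far from indifferent to substitution. Among these compounds, a single bromine atom on an aromatic carbon, para to a large group, moves the number upward, whereas the only earlier single change, a 6.0-fold lower number from compound 2 to compound 3 (0.78 log units; beyond the scatter), moved it downward on a different ring and by a smaller step. Nothing shown here accounts for this large rise.

The compounds shown leave open whether a fluoro, a methoxy or an amine on the same carbon would stay close to compound 3 or rise as compound 4 does. They also leave open whether the bromo would have a comparable effect on compound 2, which carries a hydrogen in place of the fluoro.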